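A 3-carbamoylcyclobutyl group replaces 4-hydroxycyclohexyl in compound 1

The compounds below may be only part of what the source reports. "The series", "measured", "known", "first", "only" and "open" are said of these compounds alone.

Measured so far in an ADME assay on S9 fraction from liver (Rattus norvegicus) for metabolic stability, with a stated time of 1 h; a lower number here means that less of the compound is left, a higher number that more of the compound is left
compound 1 `N#Cc1cnc(NCc2ccccc2C(F)(F)F)cc1N[C@H]1CC[C@@H](O)CC1` gives 31%
compound 2 `CO[C@H]1CC[C@@H](Nc2cc(NCc3cnccc3C(F)(F)F)ncc2C#N)CC1` gives 1%
compound 3 `N#Cc1cnc(NCc2cnccc2C(F)(F)F)cc1NC[C@H]1CC[C@@H](O)CC1` gives 18%

Compound 1 holds the highest number of these three, and its gaps to compound 2 and compound 3 both lie beyond the usual scatter. Compound 4 `N#Cc1cnc(NCc2ccccc2C(F)(F)F)cc1N[C@H]1C[C@@H](C(N)=O)C1` keeps the rest of compound 1 and changes one group: 3-carbamoylcyclobutyl in place of 4-hydroxycyclohexyl on a nitrogen on an aromatic ring. Going by the values given here, no measured compound carries the 3-carbamoylcyclobutyl group, so direct evidence is lacking.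

Among the compounds with values here, only one measured step involves a change on this nitrogen: a number 17 percentage points higher from compound 2 to compound 3 (beyond the scatter). That step is modest but beyond the scatter. It swaps different groups, however, and both of its compounds also differ from compound 1 elsewhere, so it offers only weak guidance. It suggests a tentative rise of similar size, though a fall cannot be ruled out. The expected step is a number 14 percentage points higher from compound 1 to compound 4 (beyond the scatter). For compound 4 the estimated value is 45%, with an expected range from 20% to 75%.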

Compound 4, percent of the compound remaining: 83%
The estimate for compound 4 lay 38 percentage points below the measured number; the whole stated range lies below it.
By their numbers in this assay, from the lowest: compound 2; then compound 3; then compound 1; then compound 4.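

In this assay the step of a number 52 percentage points higher from compound 1 to compound 4 (beyond the scatter) shows that this group on a nitrogen on an aromatic ring can strongly change the result while the rest of compound 1 stays the same. The entering and leaving groups have equal counts of heavy atoms, hydrogen-bond donors and hydrogen-bond acceptors, so those counts alone do not separate compound 1 from compound 4, whereas the ring size and the functional group do differ. Nothing available here explains the rise.

The compounds shown leave open whether the four-membered ring, the carbamoyl group or the two together account for the step; a 3-hydroxycyclobutyl group, a 4-carbamoylcyclohexyl group, or a carboxylic acid or amine in place of the carbamoyl group could help separate these. As far as these compounds go, it also remains open whether the same swap would raise the number on the rest of compound 2 or compound 3.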